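Removing a methyl from an oxygen: three compounds and one prediction

This account rests on a few compounds, and the source may have more. Where it says the series, first, only, none or still open, it means among the compounds named here.

Compound 1, `COc1cc2cc(-c3ccc4cccc(O)c4n3)[nH]c2cc1OC`, gives 5.2 10^-6 cm/s in an ADME assay for permeability, using PAMPA, with a stated time of 10 h, tested at 100 ug/mL; a higher number here means that the compound crosses the layer faster, a lower number that the compound crosses the layer more slowly.
Compound 2, `COc1cc2[nH]c(-c3ccc4cccc(O)c4n3)cc2cc1O`, gives 12.1 10^-6 cm/s.
Compound 3, `COc1cc2cc(-c3ccc4c(Cl)cc(Cl)c(O)c4n3)[nH]c2cc1OC`, gives 3.9 10^-6 cm/s.

Compound 2 differs from compound 1 by hydrogen in place of methyl on an oxygen on an aromatic ring, and this change brought a 2.3-fold higher number from compound 1 to compound 2 (0.37 log units; beyond the scatter). Compound 3 and compound 1 lie within the usual scatter of each other, while compound 2 stands beyond both. The difference between the core of compound 3 and that of compound 1 is not broken down here.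

Compound 4, `COc1cc2[nH]c(-c3ccc4c(Cl)cc(Cl)c(O)c4n3)cc2cc1O`, has not been measured yet. It differs from compound 3 by hydrogen in place of methyl on an oxygen on an aromatic ring, the same change as from compound 1 to compound 2, at the same place. Because the earlier step was a 2.3-fold higher number from compound 1 to compound 2 (0.37 log units; beyond the scatter), a step of a 2.2-fold higher number from compound 3 to compound 4 (0.34 log units; beyond the scatter) is expected here. Compound 4 is therefore estimated at 8.5 10^-6 cm/s, within a range from 4 10^-6 cm/s to 16 10^-6 cm/s.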

Compound 4, apparent permeability: 8.4 10^-6 cm/s
For compound 4 the middle estimate is 1.0-fold (0.01 log units) above the measured one; measured number inside the range.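

In this assay, replacing methoxy with hydroxy gave a 2.2-fold higher number from compound 3 to compound 4 (0.33 log units; beyond the scatter), and this step matches the earlier one on the other core: the same change on two cores in this assay, a 2.3-fold higher number (0.37 log units; beyond the scatter) from compound 1 to compound 2 and a 2.2-fold higher number (0.33 log units; beyond the scatter) from compound 3 to compound 4, 1.1-fold (0.03 log units) apart, within the scatter of two such steps. In these two pairs, then, the change carried over from the core of compound 1 to the core of compound 3 with its size kept. This does not show why the number goes up, and two pairs cannot establish that the same step would hold on every other core in this series.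

On these data alone, whether a longer chain on that oxygen, or an amine or a carboxylic acid in place of the hydroxy, would give a similar step remains open. So does the size of this step on a core carrying other groups.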